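A few compounds are considered here, and "the series" means these few. Any claim that something is new, unique, unknown or untested is made for them only; others in the source may bear on it.

Compound 1 `COc1ccccc1N1CCN(CCC(Oc2ccc(NC(=O)c3ccccc3OCCCC(=O)O)cc2)c2ccccc2)CC1`, compound 2 `COc1ccccc1N1CCN(CCC(Oc2ccc(NC(=O)c3ccccc3OCCCC(=O)O)cc2)c2ccc(C)cc2)CC1` and compound 3 `COc1ccccc1N1CCN(CCC(Oc2ccc(C(=O)Nc3ccccc3OCCCC(=O)O)cc2)c2ccccc2)CC1` were measured in an assay on Prostate gland (Oryctolagus cuniculus) for inhibition of Adrenergic receptor alpha-1 (Homo sapiens); a lower number here means tighter binding, a higher number weaker binding. In this assay compound 1 gives 79.4 nM, compound 2 gives 79.4 nM and compound 3 gives 25.1 nM.

Compound 3 stands lowest of the three numbers: its nearest neighbour is compound 1, and compound 2 lies just as far away, both beyond the scatter. Compound 4 `COc1ccc(C(CCN2CCN(c3ccccc3OC)CC2)Oc2ccc(C(=O)Nc3ccccc3OCCCC(=O)O)cc2)cc1` has not yet been measured. It differs from compound 3 by methoxy in place of hydrogen on an aromatic carbon, a methoxy in place of hydrogen on an aromatic carbon of a six-membered aromatic ring of carbon only, para to a large group; one bond further out this reads as phenyl to 4-methoxyphenyl.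

Among the measured compounds shown here, one measured step bears on this change. From compound 1 to compound 2 a methyl took the place of hydrogen on the same kind of aromatic carbon, and that step gave no change at the digits printed from compound 1 to compound 2 (within the scatter). A methoxy is not a methyl, so the carry-over is only partial, but the available evidence points to no step beyond the scatter. The step from compound 3 to compound 4 in this assay is therefore expected to be a 1.0-fold lower number from compound 3 to compound 4 (0.00 log units; within the scatter). Compound 4 is estimated at 25 nM, with a range from 10 nM to 63 nM, an expectation resting on compound 3 at 25.1 nM and on the flat step from compound 1 to compound 2.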

Compound 4, dissociation constant: 200 nM
Compound 4: the middle estimate sits 8.0-fold (0.90 log units) below what was measured, and the stated range ends below it.
By their numbers in this assay, from the lowest: compound 3; then compounds 1 and 2 (each within the scatter of the next); then compound 4.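

In this assay, placing a methoxy on this aromatic carbon, para to a large group, does not leave binding untouched: the result is an 8.0-fold higher number from compound 3 to compound 4 (0.90 log units; beyond the scatter), which moves compound 4 past every other compound shown. The earlier pair had suggested that this ring position was indifferent to substitution, with methyl in place of hydrogen giving no change at the digits printed from compound 1 to compound 2 (within the scatter), but that step now holds only for methyl on the core of compound 1 and does not extend to methoxy on the core of compound 3. The two steps differ in both the entering group and the core, and nothing available explains the loss in binding.

On these data alone, it remains open whether a methyl at this place on the core of compound 3 would stay as flat as it did on the core of compound 1, and whether a methoxy on the core of compound 1 would repeat the step seen here. A fluorine, a hydroxyl or a longer ether chain on the same carbon would help show whether this step belongs to methoxy alone or extends to other groups in place of hydrogen.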